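A few compounds are considered here, and "the series" means these few. Any claim that something is new, unique, unknown or untested is made for them only; others in the source may bear on it.

Working notes on the series. Within the data shown here, in an assay on CHO cells for displacement of a labelled ligand from adenosine receptor A3 (Homo sapiens), read by scintillation counting (on this read-out lower numbers stand for stronger inhibition and higher numbers for weaker inhibition), compound 2 `O=C(Nc1nc(-c2ccccc2)nc2c1nnn2Cc1ccccc1)c1cccc(F)c1` gives 5810 nM, the larger of the two numbers so far, while compound 1 `O=C(Nc1nc(-c2ccccc2)nc2c1nnn2Cc1ccccc1)c1cccc([N+](=O)[O-])c1` gives 4850 nM; the step of a 1.2-fold higher number from compound 1 to compound 2 (0.08 log units; within the scatter) stays within the scatter. Compound 3 `O=C(Nc1nc(-c2ccccc2)nc2c1nnn2Cc1ccccc1)c1cccc(C(F)(F)F)c1` differs from compound 2 by trifluoromethyl in place of fluoro on an aromatic carbon. Among the measured compounds shown here, the only step that bears on this swap of one group for another on that aromatic carbon, a 1.2-fold higher number from compound 1 to compound 2 (0.08 log units; within the scatter), did not move the number beyond the scatter, so no step beyond the scatter is expected in this assay. Compound 3 is therefore estimated at 5000 nM (range 1500 nM to 16000 nM), an expected step of a 1.2-fold lower number from compound 2 to compound 3 (0.07 log units; within the scatter).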

Compound 3, inhibition constant: 2510 nM
Estimate against measurement, compound 3: 2.0-fold (0.30 log units) above; the range from low to high includes it.
By their numbers in this assay, from the lowest: compounds 3, 1 and 2 (each within the scatter of the next, the first and the last beyond it).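

In this assay, among these compounds, swapping the group on this aromatic carbon can move the number beyond the scatter, though only modestly: trifluoromethyl in place of fluoro gives the first such step (a 2.3-fold lower number from compound 2 to compound 3 (0.36 log units; beyond the scatter)). Trifluoromethyl in place of nitro does not separate the two compounds (a 1.9-fold lower number from compound 1 to compound 3 (0.29 log units; within the scatter)), so only the fluoro and trifluoromethyl pair is distinguished. No evidence in hand bears on this result.

On these data alone, how an amine or a carboxylic acid on this aromatic carbon would read stays open. So does whether the step from 3-fluorophenyl to 3-(trifluoromethyl)phenyl holds on any other core.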